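Enlarging the Ring on the Aromatic Nitrogen

A few compounds are considered here, and "the series" means these few. Any claim that something is new, unique, unknown or untested is made for them only; others in the source may bear on it.

Of the compounds shown here, three built on a shared core have been measured: compound 1 `CC(C)c1onc(-c2c(Cl)cccc2Cl)c1COc1ccc(-c2nc3cc(C(=O)O)ccc3n2C)cc1`, compound 2 `CC(C)c1onc(-c2c(Cl)cccc2Cl)c1COc1ccc(-c2nc3ccc(C(=O)O)cc3n2C2CC2)cc1` and compound 3 `CC(C)c1onc(-c2c(Cl)cccc2Cl)c1COc1ccc(-c2nc3ccc(C(=O)O)cc3n2C)cc1Cl`. In an assay on HEK-293T cells for antagonist activity at vitamin D3 receptor (Homo sapiens), read by a luciferase reporter, with a stated time of 24 h (on this read-out lower numbers stand for stronger inhibition and higher numbers for weaker inhibition), compound 1 gives 4410 nM, compound 2 gives 3200 nM and compound 3 gives 2450 nM. Compound 2 stands second highest of the three numbers, yet its gaps to compound 3 and to compound 1 both lie within the usual scatter, so the three cannot really be told apart. Compound 4 `CC(C)c1onc(-c2c(Cl)cccc2Cl)c1COc1ccc(-c2nc3ccc(C(=O)O)cc3n2C2CCCC2)cc1` differs from compound 2 in one place: cyclopentyl in place of cyclopropyl on an aromatic nitrogen. Among the measured compounds shown here, no measured pair shows what such a change does, so the step in this assay is expected to be small, with no clear direction, and probably not beyond the scatter. Compound 4 is expected to give about 2800 nM, within 1200 nM to 7000 nM. That would mean an expected step of a 1.1-fold lower number from compound 2 to compound 4 (0.06 log units; within the scatter).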

Compound 4, half-maximal inhibitory concentration: 929 nM
Compound 4: the middle estimate sits 3.0-fold (0.48 log units) above what was measured; measured number outside the range, below it.
By their numbers in this assay, from the lowest: compound 4; then compounds 3, 2 and 1 (each within the scatter of the next).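

On this aromatic nitrogen, the choice of ring matters in this assay: cyclopentyl in place of cyclopropyl gives a 3.4-fold lower number from compound 2 to compound 4 (0.54 log units; beyond the scatter). The earlier compounds shown here differ from one another in more than one place, so they could not show this single change at work. Nothing here explains why the number falls. Going by these compounds, with only these two rings compared at this position, it remains open whether the number follows ring size. Cyclobutyl, cyclohexyl or an open isopropyl chain on the same nitrogen would test that.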